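The compounds below may be only part of what the source reports. "The series", "measured", "known", "first", "only" and "open" are said of these compounds alone.

Measured so far:
compound 1, `COc1cc(C)cc(-c2c(-c3ccnc(-c4ccc(C(C)=O)cc4)c3)cnn2CC#N)c1`, gives 95%
compound 2, `Cc1cc(O)cc(-c2nn(CC#N)cc2-c2ccnc(-c3ccc(Oc4ccccc4)cc3)c2)c1`, gives 89%

Both numbers come from a functional assay on NCI-H322M cells (Homo sapiens) for cytotoxicity, read by sulforhodamine B assay, with a stated time of 48 h, tested at 0.01 uM; a higher number here means a weaker effect of the compound at the concentration tested, a lower number a stronger effect. Of the two, compound 1 carries the higher number, but its gap to compound 2 lies within the scatter, so the two compounds cannot be told apart on the effect at this concentration; both leave most of the cell growth intact.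

Compound 3, `COc1cc(C)cc(-c2c(-c3ccnc(-c4ccc(N(C)C)cc4)c3)cnn2CC#N)c1`, has not yet been run in this assay. It differs from compound 1 in one place: dimethylamino in place of acetyl on an aromatic carbon. Within the data shown here, no pair of measured compounds shows what this change does to the read-out, and the two numbers in hand sit close together near the weak end.

With nothing measured to argue for a shift, the expectation for the step of a number 3 percentage points lower from compound 1 to compound 3 (within the scatter) is none beyond the scatter. Compound 3 is estimated at 92%, with a range from 76% to 105%.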

Compound 3, a percentage reported as activity, at one concentration (the size of the read-out at that concentration, not a potency): 83%
For compound 3 the middle estimate is 9 percentage points above the measured one, within the range that was stated.
By their numbers in this assay, from the lowest: compounds 3, 2 and 1 (each within the scatter of the next, the first and the last beyond it).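

In this assay, dimethylamino in place of acetyl on an aromatic carbon, para to a large group, gives a number 12 percentage points lower from compound 1 to compound 3 (beyond the scatter), the first sign that the read-out responds to a change at this position. The two groups match in heavy-atom count, hydrogen-bond acceptor count and lack of net charge, so those counts alone do not fix the read-out here, and compound 3 at 83% still stands near the weak end. No measurement shown bears on the cause of this shift.

Open, going by these compounds, is whether the step comes from gaining dimethylamino or from losing acetyl, which a primary amine, a carboxylic acid or a longer chain such as diethylamino on the same carbon could help separate. Also open, on these data alone, is whether the same change would give a step of similar size on the core of compound 2.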